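One Swap on the Shared Core: Chloro to Nitro

The compounds below may be only part of what the source reports. "The series", "measured", "known", "first", "only" and "open" are said of these compounds alone.

For the measured compounds named here, compound 2 `Clc1ccc(N2CCN(CCCOc3ccc4c(c3)CCC4)CC2)cc1` is the lower of the two measured members. In a functional assay on the whole organism for inhibition, with Mus musculus as the target, at a dose of 25 mg/kg by the oral route (on this read-out higher numbers stand for more inhibition at the one dose given (going by the name of the read-out) and lower numbers for less inhibition), compound 2 gives 43%, while compound 1 `c1ccc(N2CCN(CCCCOc3ccc4c(c3)CCC4)CC2)cc1` gives 75%, a gap beyond the usual scatter. Compound 3 `O=[N+]([O-])c1ccc(N2CCN(CCCOc3ccc4c(c3)CCC4)CC2)cc1` is not yet measured; it differs from compound 2 in one place: nitro in place of chloro on an aromatic carbon. Going by the values given here, no measured pair shows this swap, so its effect is uncertain. The expected step here, a number 2 percentage points higher from compound 2 to compound 3 (within the scatter), is one of no clear direction beyond the scatter. Compound 3 is therefore estimated at 45%, between 15% and 75%.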

Compound 3, a percentage reported as inhibition, in the whole organism at one dose (the size of the read-out at that dose, not a potency): 0%
Estimate against measurement, compound 3: 45 percentage points above, outside the stated range (below it).
By their numbers in this assay, from the lowest: compound 3; then compound 2; then compound 1.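

The swap from 4-chlorophenyl to 4-nitrophenyl is the only single-place change shown in this series, and in this assay it gives a number 43 percentage points lower from compound 2 to compound 3 (beyond the scatter). This position is therefore not indifferent to what sits on it: with the rest of the molecule unchanged, this one swap moves the read-out beyond the scatter. No measurement here bears on what lies behind this drop. Still open, from the compounds shown here alone, is how an amine, a methoxy group or a nitrile would read at this position, and whether the same swap would have a similar effect on a longer chain.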